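Aryl replacement at the amine-bound chain carbon

The source may report more compounds than this note shows. Statements on the series, on what has been measured and on what is new or still open speak of the compounds shown alone.

Measured compounds:
- compound 1 `O=S(=O)(NCCCNCc1ccc(Cl)c(C(F)(F)F)c1)c1cc(C(F)(F)F)cc(C(F)(F)F)c1` gives 10000 nM in a functional assay on PANC-1 cells (Homo sapiens) for inhibition, read by MTT assay, with a stated time of 72 h; a higher number here means a weaker inhibitor of growth, a lower number a stronger inhibitor of growth
- compound 2 `O=S(=O)(NCCCNCc1ccc(C(F)(F)F)cc1)c1cc(C(F)(F)F)cc(C(F)(F)F)c1` gives 3200 nM in this assay
- compound 3 `O=S(=O)(NCCCNCc1cccc2ccccc12)c1cc(C(F)(F)F)cc(C(F)(F)F)c1` gives 2700 nM in this assay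

Compound 3 holds the lowest number of the three. Its nearest neighbour is compound 2, and that gap, a 1.2-fold lower number from compound 2 to compound 3 (0.07 log units; within the scatter), is within the scatter, so no order between compound 2 and compound 3 is claimed. The furthest is compound 1, with a 3.7-fold lower number from compound 1 to compound 3 (0.57 log units; beyond the scatter) beyond the scatter.

Compound 4 `COc1ccc(CNCCCNS(=O)(=O)c2cc(C(F)(F)F)cc(C(F)(F)F)c2)cc1` differs from compound 3 only at the aryl group: 4-methoxyphenyl in place of naphthalen-1-yl on a saturated chain carbon bound to an amine nitrogen. All three measured steps are aryl exchanges at this same place and bear on it: a 3.1-fold lower number from compound 1 to compound 2 (0.49 log units; beyond the scatter), a 3.7-fold lower number from compound 1 to compound 3 (0.57 log units; beyond the scatter) and a 1.2-fold lower number from compound 2 to compound 3 (0.07 log units; within the scatter). None exceeds a modest size, and compound 3 sits at the low end of the range covered. A step of comparable size is therefore expected in this assay, more likely toward a higher number than a lower one; the expected step is a 1.7-fold higher number from compound 3 to compound 4 (0.22 log units; within the scatter). Compound 4 is estimated at 4500 nM, with a range from 1800 nM to 12000 nM.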

Compound 4, concentration for 50% growth inhibition: 11000 nM
For compound 4 the middle estimate is 2.4-fold (0.39 log units) below the measured one; low and high end bracket the measured number.
By their numbers in this assay, from the lowest: compounds 3 and 2 (each within the scatter of the next); then compounds 1 and 4 (each within the scatter of the next).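

In this assay, a substituent on a single aryl ring at this position does not by itself hold the number down: methoxy in place of trifluoromethyl gives a 3.4-fold higher number from compound 2 to compound 4 (0.54 log units; beyond the scatter), and the exchange from naphthalen-1-yl gives a 4.1-fold higher number from compound 3 to compound 4 (0.61 log units; beyond the scatter). The 4-methoxyphenyl and 4-chloro-3-(trifluoromethyl)phenyl groups cannot be ordered, with a 1.1-fold higher number from compound 1 to compound 4 (0.04 log units; within the scatter), so the four compounds now fall into two levels, compounds 2 and 3 at the lower and compounds 1 and 4 at the higher. Nothing available accounts for this split.

Open, on these data alone, is whether a nitrile, a hydroxyl or a fluorine on the same aryl ring would join the lower or the higher level. Also open, as far as these compounds go, is whether these two levels persist with a longer chain in the shared core.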